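The compounds below may be only part of what the source reports. "The series", "measured", "known", "first", "only" and "open" are said of these compounds alone.

Compound 1 `Cn1cc(C2CC(c3ccccc3)=NN2C(=O)c2cccnc2)c2ccccc21` and compound 2 `Cc1ccc(C(=O)N2N=C(c3ccccc3)CC2c2cn(C)c3ccccc23)cn1` share one core. In a functional assay on MCF7 cells (Homo sapiens) for inhibition, read by MTT assay, with a stated time of 48 h (a higher number here means a weaker inhibitor of growth, a lower number a stronger inhibitor of growth), compound 1 gives 7200 nM, and compound 2 gives 4010 nM. The change between them is methyl in place of hydrogen on an aromatic carbon, and the step it made is a 1.8-fold lower number from compound 1 to compound 2 (0.25 log units; within the scatter), so the two numbers cannot be told apart with confidence.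

Compound 3 `COc1cccc(C2=NN(C(=O)c3cccnc3)C(c3cn(C)c4ccc(OC)cc34)C2)c1` stands on a second core; the difference between the two cores is not broken down here. In this assay compound 3 gives 810 nM, the lowest of the three numbers, with its gaps to compound 2 and to compound 1 both beyond the scatter.

Compound 4 `COc1cccc(C2=NN(C(=O)c3ccc(C)nc3)C(c3cn(C)c4ccc(OC)cc34)C2)c1` is not yet measured. It differs from compound 3 by methyl in place of hydrogen on an aromatic carbon. The place of the change is described in the same words as for the pair compound 1 to compound 2, so this is the same change applied to the second core. Among the compounds with values here, only that one earlier instance is available, and it lay within the scatter, so no direction can be claimed from it.

The step from compound 3 to compound 4 is expected to be a 1.5-fold lower number from compound 3 to compound 4 (0.17 log units; within the scatter) because a 1.8-fold lower number from compound 1 to compound 2 (0.25 log units; within the scatter) was small. For compound 4 in this assay the estimate is 550 nM. For compound 4 the expected range runs from 250 nM to 1500 nM, with no limit value expected.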

Compound 4, concentration for 50% growth inhibition: 90 nM
Beside the measured number, compound 4's estimate is 6.1-fold (0.79 log units) above it, and the stated range ends above it.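

In this assay, the change from pyridin-3-yl to 6-methylpyridin-3-yl on the second core gives a 9.0-fold lower number from compound 3 to compound 4 (0.95 log units; beyond the scatter), so the size of the step does not carry over unchanged from one core to the other: the same change on two cores in this assay, a 1.8-fold lower number (0.25 log units; within the scatter) from compound 1 to compound 2 and a 9.0-fold lower number (0.95 log units; beyond the scatter) from compound 3 to compound 4, 5.0-fold (0.70 log units) apart, beyond the scatter of two such steps

On the first core, the step (a 1.8-fold lower number from compound 1 to compound 2 (0.25 log units; within the scatter)) cannot be separated from the scatter, so only the second core gives a clear effect of the methyl, and a shared direction across the two cores is not established. With a single pair on each core, this shows that the size of the step differed between these two cores, but it gives no rule for any other core and does not show which feature of the second core goes with the larger step.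

The compounds shown leave open which part of the difference between the core of compound 1 and the core of compound 3 goes with the larger step, since no compound separates the parts of that difference. They also leave open whether the larger step belongs to methyl alone or extends to other groups at the same place, such as ethyl, chlorine, an amine or a carboxylic acid.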